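Swapping the aryl group on a glycoside-linked triazole series

The source may report more compounds than this note shows. Statements on the series, on what has been measured and on what is new or still open speak of the compounds shown alone.

This small set of compounds shares a core in which a cyclohexyl-bearing amine sits on a five-membered aromatic ring with two nitrogens and one oxygen, and the set was tested in an ADME assay on RAW264.7 cells (Mus musculus) for cytotoxicity, read by MTT assay, with a stated time of 48 h; on this read-out lower numbers stand for higher toxicity in this test and higher numbers for lower toxicity in this test. Compound 1 `C#CCN(c1nc(-c2cccc(C)c2)no1)C1CCCCC1` gives 25.9 ug/mL in this assay. Compound 3 `C#CCN(c1nc(-c2ccc(C#C)cc2)no1)C1CCCCC1` gives 13.1 ug/mL in this assay. Compound 2 `CC(=O)OC[C@H]1O[C@H](OC[C@@H](Cn2cc(CN(c3nc(-c4cccc(C)c4)no3)C3CCCCC3)nn2)OC(C)=O)C=C[C@@H]1OC(C)=O`, which carries a larger sugar-bearing side chain, gives 46.4 ug/mL in this assay, the highest of the three numbers; its gap to compound 1 lies within the usual scatter, while its gap to compound 3 lies beyond it.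

Compound 4 `CC(=O)OC[C@H]1O[C@H](OC[C@@H](Cn2cc(CN(c3nc(-c4ccc(C(F)(F)F)cc4)no3)C3CCCCC3)nn2)OC(C)=O)C=C[C@@H]1OC(C)=O` has not yet been measured. It differs from compound 2 in one place: 4-(trifluoromethyl)phenyl in place of 3-methylphenyl on an aromatic carbon. Among the measured compounds shown here, no measured pair in this set isolates this same change, so the size of the step is uncertain. A modest move toward a lower number is expected, though it may well stay within the scatter, giving an expected step of a 1.4-fold lower number from compound 2 to compound 4 (0.15 log units; within the scatter) in this assay. For compound 4 the estimate in this assay is 33 ug/mL, with a range from 14 ug/mL to 75 ug/mL.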

Compound 4, half-maximal cytotoxic concentration: 64.1 ug/mL
Beside the measured number, compound 4's estimate is 1.9-fold (0.29 log units) below it, within the range that was stated.
By their numbers in this assay, from the lowest: compounds 3, 1, 2 and 4 (each within the scatter of the next, the first and the last beyond it).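

Within the sugar-bearing series, putting 4-(trifluoromethyl)phenyl in place of 3-methylphenyl on the aromatic carbon of the shared core gives a 1.4-fold higher number from compound 2 to compound 4 (0.14 log units; within the scatter) in this assay, so this swap leaves the read-out within the usual scatter. Among the compounds shown here, this is the first direct look at this position with the sugar-bearing side chain held constant, and the number stays in the same range despite the change of aryl group. The swap alters both the group on the phenyl ring and where it sits, and no explanation for the result is available from measurements of any property.

Still open, going by these compounds, is how 4-methylphenyl or 3-(trifluoromethyl)phenyl would read here, since either would separate the group from its location on the phenyl ring. A phenyl ring carrying an amine or a carboxylic acid would also test whether this position accepts groups of a quite different kind.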